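This account rests on a few compounds, and the source may have more. Where it says the series, first, only, none or still open, it means among the compounds named here.

The measured compounds, each with its result in a functional assay on the whole organism (stomach) for inhibition, with Canis familiaris (Canis lupus familiaris) as the target, at a dose of 5 mg/kg by the intravenous route; a higher number here means a stronger effect of the compound at the dose given, a lower number a weaker effect:

compound 1 `Cc1nc2c(OCc3ccccc3)cccn2c1C(N)=O` — 2%
compound 2 `CC(=O)c1c(C)nc2c(OCc3ccccc3)cccn12` — 9%
compound 3 `COCc1c(C)nc2c(OCc3ccccc3)cccn12` — 29%

Compound 1 stands lowest of the three in this assay. Its nearest neighbour is compound 2, which lies a number 7 percentage points higher from compound 1 to compound 2 (within the scatter) through methyl in place of amino on a carbonyl carbon, a step within the scatter. The furthest is compound 3, which lies a number 27 percentage points higher from compound 1 to compound 3 (beyond the scatter) through methoxymethyl in place of carbamoyl on an aromatic carbon, a modest step beyond the scatter. The related change from the acetyl compound also moves the number, with compound 3 lying a number 20 percentage points higher from compound 2 to compound 3 (beyond the scatter).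

The unmeasured compound 4 `CCOCc1c(C)nc2c(OCc3ccccc3)cccn12` differs from compound 1 in this way: ethoxymethyl in place of carbamoyl on an aromatic carbon. Within the data shown here, the step that bears most directly on it is the one from compound 1 to compound 3, where methoxymethyl in place of carbamoyl gave a modest rise beyond the scatter. Compound 4 carries an ethoxymethyl group on the same aromatic carbon, and so a step of similar size and in the same direction is expected, as an estimated a number 28 percentage points higher from compound 1 to compound 4 (beyond the scatter). Compound 4 is therefore expected to give about 30% in this assay, with a range from 12% to 48%.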

Compound 4, a percentage reported as inhibition, in the whole organism at one dose (the size of the read-out at that dose, not a potency): 35%
Compound 4: the middle estimate sits 5 percentage points below what was measured, and the stated range covers the measured number.
By their numbers in this assay, from the lowest: compounds 1 and 2 (each within the scatter of the next); then compounds 3 and 4 (each within the scatter of the next).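

In this assay, the ethoxymethyl group on this aromatic carbon confirms that the rise seen with methoxymethyl is not confined to that one ether: compound 4 lies a number 33 percentage points higher from compound 1 to compound 4 (beyond the scatter) and a number 26 percentage points higher from compound 2 to compound 4 (beyond the scatter), so both compounds with an ether side chain now stand clear of both compounds with a carbonyl group at this position, with no exception among the four. The chain itself can also carry an added methyl with no separable effect, since the result lies a number 6 percentage points higher from compound 3 to compound 4 (within the scatter), and the two ether compounds cannot be ranked against each other. No measurement offered here accounts for the difference between the ether and carbonyl groups at this position.

As far as these compounds go, it remains open whether the chain can grow further, as in a propoxymethyl or butoxymethyl group, before the number changes beyond the scatter. From the compounds shown here alone, it also remains open whether the ether oxygen matters at all, which a plain propyl chain could test, and how a hydroxymethyl group or an aminomethyl group would compare at this position.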